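A few compounds are considered here, and "the series" means these few. Any claim that something is new, unique, unknown or untested is made for them only; others in the source may bear on it.

Measured so far in a functional assay on HeLa cells (Homo sapiens) for antiproliferative activity, read by MTT assay, with a stated time of 72 h; a lower number here means a stronger inhibitor, a higher number a weaker inhibitor:

- compound 1 `COc1cc(-c2ncnn2-c2ccc(Cl)c(Cl)c2)cc(OC)c1OC`: > 10000 nM, a limit of the assay, not a number
- compound 2 `COc1cc(-c2ncnn2-c2ccc(Cl)cc2Cl)cc(OC)c1OC`: > 10000 nM, likewise a limit
- compound 3 `COc1cc(-c2ncnn2-c2ccc(Cl)cc2)cc(OC)c1OC`: > 10000 nM, likewise a limit

All three values sit at the same limit, as the limit of > 10000 nM in this assay, at which 3 of the 3 values shown sit, records. The measured steps therefore give no readable size: a step that the two limits leave unreadable from compound 1 to compound 2, a step that the two limits leave unreadable from compound 1 to compound 3 and a step that the two limits leave unreadable from compound 2 to compound 3 are all unreadable between the two limits. Compound 3 thus stands only at a limit, with no number to place it against the other two.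

The next compound is compound 4 `COc1cc(-c2ncnn2-c2cccc(F)c2)cc(OC)c1OC`. It differs from compound 3 as follows: 3-fluorophenyl in place of 4-chlorophenyl on an aromatic nitrogen. Each of the measured steps concerns a change of the same aryl group on the same aromatic nitrogen, and none of them moved any compound off the limit, so they bear on this step only in that they show no change large enough to be seen. No step beyond the scatter is expected from compound 3 to compound 4 in this assay, and the expected result is again a limit rather than a number; the estimated step is a step that the limit leaves unreadable from compound 3 to compound 4. For compound 4 the estimate in this assay is 15000 nM, with a range from 5000 nM to 50000 nM.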

Compound 4, half-maximal inhibitory concentration: > 10000 nM
Compound 4: only a limit was reported; the forecaster's own chance of this, stated with the estimate: 85%; the middle value is on the limit's open side.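

In this assay compound 4 gives > 10000 nM, a limit and not a number. Its steps from compound 1, compound 2 and compound 3 cannot be read: the limit of > 10000 nM in this assay, at which 4 of the 4 values shown sit.

The compounds shown leave open whether any aryl group on the aromatic nitrogen gives a readable value in this assay.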